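The source may hold more compounds than are shown below. What is called first, only, known or untested is meant among the compounds shown, and "the series" means these compounds.

Measured so far:
- compound 1, `Cc1c(Cc2ccccc2)c(=O)oc2cc(OCC(CN3CCC(C(N)=O)CC3)Oc3ccccc3F)ccc12`, in an ADME assay on A549 cells (Homo sapiens) for cytotoxicity, read by CellTiter-Glo (on this read-out higher numbers stand for lower toxicity in this test and lower numbers for higher toxicity in this test), gives 79600 nM
- compound 2, `Cc1c(Cc2ccccc2)c(=O)oc2cc(OCC(CN3CCC(C(N)=O)CC3)Oc3ccc([N+](=O)[O-])cc3)ccc12`, in this assay gives 94800 nM

Among the compounds with values here, compound 2 has the highest of the two numbers, but its only neighbour, compound 1, sits within the scatter of it: the one measured step, a 1.2-fold higher number from compound 1 to compound 2 (0.08 log units; within the scatter), is too small to count as a real change. Compound 3, `Cc1c(Cc2ccccc2)c(=O)oc2cc(OCC(CN3CCC(C(N)=O)CC3)Oc3ccc(-c4ncc(N)s4)cc3)ccc12`, is not yet measured. It differs from compound 2 by 5-amino-1,3-thiazol-2-yl in place of nitro on an aromatic carbon, that is, on the phenyl ring attached through oxygen to a saturated carbon, the same ring that was altered in the step from compound 1 to compound 2. Within the data shown here, that step, which also changed only this ring's substituent, stayed within the scatter, so a step of a similar small size, in no clear direction, is the expectation for a 1.4-fold lower number from compound 2 to compound 3 (0.13 log units; within the scatter). Compound 3 is therefore estimated at 70000 nM, with a range from 30000 nM to 160000 nM.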

Compound 3, half-maximal cytotoxic concentration: > 100000 nM
Compound 3 was reported as a limit; the forecaster's own chance of this, stated with the estimate: 25%; middle value at least 1.4-fold (0.15 log units) away from the limit.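

In this assay, compound 3 is reported only as a limit and not as a number: the limit of > 100000 nM in this assay, at which 1 of the 3 values shown sits. Read as floors, the new steps are an at least 1.0-fold higher number from compound 2 to compound 3 (0.02 log units; that floor lies within the scatter) and an at least 1.2-fold higher number from compound 1 to compound 3 (0.09 log units; that floor lies within the scatter), so neither shows a real change. What this adds is that replacing nitro, which has no ring, with 5-amino-1,3-thiazol-2-yl, which brings a five-membered aromatic ring, gave no lower number at this place on the phenyl ring, and so no sign of higher toxicity in this test.

From the compounds shown here alone, how large the step from nitro to this ring really is remains open, since only its floor can be read. Also open, going by these compounds, is whether a carboxylic acid or a simple amine at this place on the phenyl ring would give a number as high.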